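The source may hold more compounds than are shown below. What is called first, only, known or untested is meant among the compounds shown, and "the series" means these compounds.

Measured compounds:
Compound 1, `CCOC(=O)c1ccc(-c2nn(C)c3ccccc23)cc1`, in a functional assay on cells (Platelet, Homo sapiens) for inhibition (a higher number here means a weaker inhibitor, a lower number a stronger inhibitor), gives > 10000 nM, which is a limit of the assay rather than a number.
Compound 2, `CCOC(=O)c1ccc(-c2nn(Cc3ccc(OC)cc3)c3ccccc23)cc1`, in this assay gives > 10000 nM, also a limit.
Compound 3, `CCOC(=O)c1ccc(-c2nn(Cc3cccnc3)c3ccccc23)cc1`, in this assay gives > 10000 nM, again a limit.

Compound 3 thus stands at the limit of the assay, and the two other measured compounds stand there as well, as shown by the limit of > 10000 nM in this assay, at which 3 of the 3 values shown sit. Compound 4, `CCOC(=O)c1ccc(-c2nn(-c3ccccc3)c3ccccc23)cc1`, differs from compound 3 in one place: phenyl in place of (pyridin-3-yl)methyl on an aromatic nitrogen. The measured steps that come nearest to this change are the ones altering the group on the saturated chain carbon bound to the aromatic nitrogen: a step that the two limits leave unreadable from compound 1 to compound 2, a step that the two limits leave unreadable from compound 1 to compound 3 and a step that the two limits leave unreadable from compound 2 to compound 3. None of them has a readable size, so no step size can be taken from them, and the change to compound 4 is of a different kind, placing phenyl on the aromatic nitrogen itself. Compound 4 is expected to remain near the limit, and the expected step is a step that the limit leaves unreadable from compound 3 to compound 4. Compound 4 is therefore estimated at 15000 nM, with a range from 4000 nM to 60000 nM.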

Compound 4, half-maximal inhibitory concentration: > 10000 nM
Compound 4: a limit, no number; the forecaster's own chance of this, stated with the estimate: 75%; the middle value lies beyond the limit too.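

In this assay compound 4 gives > 10000 nM, a limit and not a number. No step from compound 1, compound 2 or compound 3 to compound 4 can be read, because all four compounds sit at the same limit: the limit of > 10000 nM in this assay, at which 4 of the 4 values shown sit.

The compounds shown leave open whether changing the group on the aromatic nitrogen alters inhibition at all.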